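Cyclohexyl Amide Expected to Recover Part of the Potency

The compounds below may be only part of what the source reports. "The series", "measured", "known", "first", "only" and "open" are said of these compounds alone.

Compound 3 `O=C(C1CCCO1)N1CCc2nc(C#Cc3ccccc3)sc2C1` carries an oxolan-2-yl group on the carbonyl carbon of an amide it shares with compound 1 `CC1CC1C(=O)N1CCc2nc(C#Cc3ccccc3)sc2C1` and compound 2 `O=C(C1CCC1)N1CCc2nc(C#Cc3ccccc3)sc2C1`. In an assay on HEK293 cells for negative allosteric modulation of metabotropic glutamate receptor 5 (Homo sapiens), read by FLIPR, with a stated time of 1 h (on this read-out higher numbers stand for weaker inhibition and lower numbers for stronger inhibition), compound 3 reaches only a limit, > 10000 nM. Compound 1 likewise sits at a limit in this assay, > 10000 nM. Compound 2, with cyclobutyl on the same carbonyl carbon, gives 370 nM in this assay; the carbocycle of compound 2 against the oxolan-2-yl of compound 3 made an at least 27-fold higher number from compound 2 to compound 3 (1.43 log units; beyond the scatter), and compound 1 against compound 2 showed an at least 27-fold lower number from compound 1 to compound 2 (1.43 log units; beyond the scatter), whereas a step that the two limits leave unreadable from compound 1 to compound 3. the limit of > 10000 nM in this assay, at which 2 of the 3 values shown sit, sets the bound on what can be read here. Compound 4 `O=C(C1CCCCC1)N1CCc2nc(C#Cc3ccccc3)sc2C1` exchanges the oxolan-2-yl for cyclohexyl: cyclohexyl in place of oxolan-2-yl on a carbonyl carbon. Cyclohexyl is a carbocycle like the cyclobutyl of compound 2, which favours a lower number, yet compound 1 shows that a small carbocycle can also remain at the limit. With compound 3 as reference, compound 4 is expected to show an at least 4.0-fold lower number from compound 3 to compound 4 (0.60 log units; beyond the scatter), with a fair chance that this assay again returns only a limit. Compound 4 is estimated at 2500 nM, within 400 nM to 10000 nM.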

Compound 4, half-maximal inhibitory concentration: > 10000 nM
Compound 4: a limit, no number; the forecaster's own chance of this, stated with the estimate: 35%; middle value at least 4.0-fold (0.60 log units) from the limit.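

In this assay cyclohexyl in place of cyclobutyl on a carbonyl carbon gave an at least 27-fold higher number from compound 2 to compound 4 (1.43 log units; beyond the scatter) and so showed that enlarging the carbocycle of compound 2 does not keep its measured number. Compound 4 has no ring oxygen and no hydrogen-bond acceptor in this group, yet it reaches only a limit, so removing the oxygen of the oxolan-2-yl in compound 3 and enlarging the ring by one atom does not by itself bring a number back. Of the four compounds, compound 2 alone has a measured number, and the steps from compound 3 to compound 4 and from compound 1 to compound 4 cannot be read, with the bound on what can be read being this: the limit of > 10000 nM in this assay, at which 3 of the 4 values shown sit.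

The compounds shown leave open whether cyclopentyl on the same carbonyl carbon would give a number, so the ring size at which the number is lost is not fixed. They also do not tell how an open chain such as isopropyl, or a phenyl ring, would read at this position in this assay.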